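The source may hold more compounds than are shown below. What is called first, only, known or untested is meant among the compounds shown, and "the series" means these compounds.

Measured compounds:
- compound 1 `COc1ccc(-c2cnc3nc(N)nc(N4CCN(C(=O)NCc5ccc(F)cc5)CC4)c3n2)cc1OC` — 37 nM
- compound 2 `COc1ccc(-c2cnc3nc(N)nc(N4CCC(C)CC4)c3n2)cc1OC` — 800 nM

In a functional assay on cells (T-cell, Homo sapiens) for inhibition (a lower number here means a stronger inhibitor, a higher number a weaker inhibitor), compound 1 gives the lowest of the two numbers; compound 2 sits at a higher value, and the gap between them lies beyond the usual scatter. The two differ in the whole group attached to the core, so what that gap shows about any single change is not separable from these data alone.

Compound 3 `COc1ccc(-c2cnc3nc(N)nc(N4CCN(Cc5c(Cl)cccc5Cl)CC4)c3n2)cc1OC` follows from compound 1 by a single change: 2,6-dichlorobenzyl in place of (4-fluorobenzyl)carbamoyl on an amine nitrogen in a ring. The group that leaves carries a hydrogen-bond donor and a hydrogen-bond acceptor; the group that enters carries neither, and brings two chlorine atoms on its aromatic ring. Among the measured compounds shown here, no measured pair isolates this change, so the expected size of the step rests only on the two values at hand.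

Compound 3 is expected to remain closer to compound 1 than to compound 2, with a modest loss of activity as the likely outcome, a step of a 4.1-fold higher number from compound 1 to compound 3 (0.61 log units; beyond the scatter). The estimate for compound 3 in this assay is 150 nM, within a range from 40 nM to 600 nM.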

Compound 3, half-maximal inhibitory concentration: 7600 nM
Estimate against measurement, compound 3: 51-fold (1.70 log units) below, outside the stated range (above it).
By their numbers in this assay, from the lowest: compound 1; then compound 2; then compound 3.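

In this assay, putting 2,6-dichlorobenzyl in place of (4-fluorobenzyl)carbamoyl on the amine nitrogen of the six-membered non-aromatic ring gives a 210-fold higher number from compound 1 to compound 3 (2.31 log units; beyond the scatter), a large step that marks this position as highly sensitive to the group it carries. Both groups hold a six-membered aromatic ring of carbon only, so the presence of such a ring at this position does not by itself preserve the activity of compound 1; the group that leaves also has a carbonyl, a hydrogen-bond donor and a hydrogen-bond acceptor, while the group that enters has neither donor nor acceptor and brings two chlorine atoms instead of one fluorine. No measurement shown here accounts for the size of the step.

The change alters the carbamoyl link and the substituents on the aromatic ring together, and the compounds shown do not tell which of these matters. As far as these compounds go, whether 4-fluorobenzyl attached directly to the same nitrogen, or (2,6-dichlorobenzyl)carbamoyl, would stay nearer to compound 1 or to compound 3 remains open.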